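Moving the ring nitrogen from compound 3 to compound 4

The source may report more compounds than this note shows. Statements on the series, on what has been measured and on what is new or still open speak of the compounds shown alone.

Of the compounds shown here, three share one core and have been tested in an ADME assay on MT4 cells (Homo sapiens) for cytotoxicity; on this read-out lower numbers stand for higher toxicity in this test and higher numbers for lower toxicity in this test. Compound 1 `C[C@@H](NC(=O)[C@H](CCCNC(=N)N)NC(=O)c1ccc(CN(Cc2ccncc2)C(=O)c2ccc(F)cc2)cc1)c1cccc2ccccc12` gives 45000 nM in this assay. Compound 2 `C[C@H](NC(=O)[C@H](CCCNC(=N)N)NC(=O)c1ccc(CN(Cc2ccncc2)Cc2ccc(F)cc2)cc1)c1cccc2ccccc12` gives 44000 nM. Compound 3 `C[C@H](NC(=O)[C@H](CCCNC(=N)N)NC(=O)c1ccc(CN(Cc2cccnc2)C(=O)c2ccc(F)cc2)cc1)c1cccc2ccccc12` gives 57000 nM, the highest of the three numbers, though its gaps to compound 1 and compound 2 both lie within the usual scatter, so none of the three is separated from the others.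

Compound 4 `C[C@H](NC(=O)[C@H](CCCNC(=N)N)NC(=O)c1ccc(CN(Cc2ccncc2)C(=O)c2ccc(F)cc2)cc1)c1cccc2ccccc12` is not yet measured. It differs from compound 3 in one place: pyridin-4-yl in place of pyridin-3-yl on a saturated chain carbon bound to an amide-type nitrogen. Within the data shown here, no measured pair shows this change in isolation. The step from compound 3 to compound 4 in this assay is expected to be small, in no particular direction, a 1.1-fold lower number from compound 3 to compound 4 (0.06 log units; within the scatter), nothing beyond the scatter. Compound 4 is therefore estimated at 50000 nM, with a range of 25000 nM to 100000 nM.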

Compound 4, half-maximal cytotoxic concentration: 51000 nM
For compound 4 the middle estimate is 1.0-fold (0.01 log units) below the measured one; measured number inside the range.
By their numbers in this assay, from the lowest: compounds 2, 1, 4 and 3 (each within the scatter of the next).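

In this assay, pyridin-4-yl in place of pyridin-3-yl gives a 1.1-fold lower number from compound 3 to compound 4 (0.05 log units; within the scatter), so this test does not tell the two groups apart at this position. (4-Fluorophenyl)carbonyl in place of 4-fluorobenzyl gives a 1.2-fold higher number from compound 2 to compound 4 (0.06 log units; within the scatter), and the stereocentre comparison gives a 1.1-fold higher number from compound 1 to compound 4 (0.05 log units; within the scatter), so neither difference separates these compounds either. The stereocentre comparison carries one caution: the fact that one of compounds 1 and 4 is drawn with a defined configuration and the other without, at the place where they differ.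

Going by these compounds, whether a pyridin-2-yl or plain phenyl group on this chain carbon would give a number beyond the scatter remains open.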